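This account rests on a few compounds, and the source may have more. Where it says the series, first, only, none or still open, it means among the compounds named here.

Measured compounds:
compound 1 `COc1cc(C#N)cc(OC(=O)N2CCC(C(c3ccccc3)c3ccccc3)CC2)c1`: > 1000 nM
compound 2 `N#Cc1cccc(OC(=O)N2CCC(C(c3ccccc3)c3ccccc3)CC2)n1`: > 1000 nM

In an assay on isolated protein for inhibition of Fatty-acid amide hydrolase 1 (Rattus norvegicus), read by fluorescence (a higher number here means a weaker inhibitor, a lower number a stronger inhibitor), compound 1 gives only a limit, > 1000 nM. Compound 2 also gives only a limit in this assay, > 1000 nM. The step that the two limits leave unreadable from compound 1 to compound 2 is not readable because of the limit of > 1000 nM in this assay, at which 2 of the 2 values shown sit.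

Compound 3 `Cc1cc(C#N)cc(OC(=O)N2CCC(C(c3ccccc3)c3ccccc3)CC2)c1` is not yet measured; it differs from compound 2 by 3-cyano-5-methylphenyl in place of 6-cyanopyridin-2-yl on an oxygen next to a carbonyl group. Going by the values given here, no measured step bears on this change, and compound 1, with 3-cyano-5-methoxyphenyl on the oxygen next to the carbonyl group, gives only a limit, > 1000 nM. Compound 3 is expected near 2500 nM, range 600 nM to 15000 nM, most likely again reported as a limit. The implied step that the limit leaves unreadable from compound 2 to compound 3 is an estimate only.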

Compound 3, half-maximal inhibitory concentration: > 1000 nM
Compound 3: a limit, no number; the forecaster's own chance of this, stated with the estimate: 70%; the middle value lies beyond the limit too.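

In this assay compound 3 gives only a limit (> 1000 nM), and the steps linking compound 1, compound 2 and compound 3 cannot be read: the limit of > 1000 nM in this assay, at which 3 of the 3 values shown sit. The compounds shown leave open whether these three differ at all in inhibition.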